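The compounds below may be only part of what the source reports. "The series", "measured", "known", "first", "only" and "open" are said of these compounds alone.

Compound 1 `Cn1nnnc1SCC(=O)N/N=C/c1ccc(Br)cc1` is reported in a functional assay on A549 cells (Homo sapiens) for cytotoxicity, read by XTT assay, with a stated time of 24 h (on this read-out higher numbers stand for weaker inhibition and lower numbers for stronger inhibition), only as a limit, > 10000000 nM.
Compound 2 `CN(C)c1ccc(/C=N/NC(=O)CSc2nnnn2C)cc1` gives 100000 nM in this assay.
Compound 3 `Cn1nnnc1SCC(=O)N/N=C/c1cccc([N+](=O)[O-])c1` is likewise reported in this assay only as a limit, > 10000000 nM.

Compound 3 thus stands at the limit of > 10000000 nM in this assay, at which 2 of the 3 values shown sit, sharing that position with compound 1. The next compound, compound 4 `Cn1nnnc1SCC(=O)N/N=C/c1cccc(Cl)c1`, differs from compound 3 by chloro in place of nitro on an aromatic carbon. Among the measured compounds shown here, the single measured step, an at least 100-fold lower number from compound 1 to compound 2 (2.00 log units; beyond the scatter), shows that a substituent on this ring can shift the number greatly, yet it concerns dimethylamino replacing bromo, not chloro replacing nitro. Compound 1, which carries a halogen on the same ring, sits at the limit. Compound 4 is therefore expected to show no step beyond the scatter, a number no higher from compound 3 to compound 4 (the limit leaves the size open). The estimate for compound 4 in this assay is 10000000 nM, between 1000000 nM and 30000000 nM.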

Compound 4, half-maximal inhibitory concentration: 7500000 nM
Compound 4: middle estimate off by 1.3-fold (0.12 log units), on the high side; the range from low to high includes it.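

With chloro in place of nitro at this position, meta to a large group, this assay now gives an actual number instead of a limit, and the step is an at least 1.3-fold lower number from compound 3 to compound 4 (0.12 log units; that floor lies within the scatter). That figure is only a floor, so the true size of the change remains unknown, and the limit still marks where compound 3 stands: the limit of > 10000000 nM in this assay, at which 2 of the 4 values shown sit.

As far as these compounds go, whether a methoxy group or a carboxylic acid at this same position would lower the number further remains open. So does how chloro would fare on other carbons of this ring.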